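The source may report more compounds than this note shows. Statements on the series, on what has been measured and on what is new or still open speak of the compounds shown alone.

Compound 1 `NCCOCCOc1ccc([C@H]2CC[C@]3(CC2)OOC2(O3)C3CC4CC(C3)CC2C4)cc1`, compound 2 `OC1(COc2ccc([C@H]3CC[C@]4(CC3)OOC3(O4)C4CC5CC(C4)CC3C5)cc2)CCNCC1` and compound 3 `CC(C)(N)CCOc1ccc([C@H]2CC[C@]3(CC2)OOC2(O3)C3CC4CC(C3)CC2C4)cc1` share one core and differ only in the group carried on a saturated chain carbon bound to an oxygen on an aromatic ring. In an ADME assay on microsomes from liver (Homo sapiens) for metabolic stability, read by LC-MS, tested at 1 uM (on this read-out lower numbers stand for slow clearance and higher numbers for fast clearance), compound 2 gives 16 mL.min-1.g-1. For compound 1 the read-out in this assay is only a limit, < 7 mL.min-1.g-1. For compound 3 the read-out is likewise a limit, < 7 mL.min-1.g-1. Compound 3 therefore stands at the floor of the assay, alongside compound 1, as set out in the limit of < 7 mL.min-1.g-1 in this assay, at which 2 of the 3 values shown sit, while compound 2 sits above it: an at least 2.2-fold higher number from compound 1 to compound 2 (0.35 log units; beyond the scatter) and an at least 2.2-fold lower number from compound 2 to compound 3 (0.35 log units; beyond the scatter) are both beyond the scatter, whereas a step that the two limits leave unreadable from compound 1 to compound 3 cannot be sized from two limits.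

Compound 4 `CC1(C)CC(O)(COc2ccc([C@H]3CC[C@]4(CC3)OOC3(O4)C4CC5CC(C4)CC3C5)cc2)CC(C)(C)N1` is still to be measured in this assay. Its change from compound 3: 4-hydroxy-2,2,6,6-tetramethylpiperidin-4-yl in place of 2-amino-2-methylpropyl on a saturated chain carbon bound to an oxygen on an aromatic ring. Going by the values given here, the one measured step that bears on it is the introduction of 4-hydroxypiperidin-4-yl in compound 2, which is an at least 2.2-fold lower number from compound 2 to compound 3 (0.35 log units; beyond the scatter) read in reverse and lifted the number off the limit. Compound 4 is accordingly expected to move off the floor by a modest step, an at least 1.7-fold higher number from compound 3 to compound 4 (0.23 log units; that floor lies within the scatter), with a fair chance that the assay again returns only a limit. The estimate for compound 4 is 12 mL.min-1.g-1, within 6 mL.min-1.g-1 to 30 mL.min-1.g-1.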

Compound 4, intrinsic clearance in microsomes in the liver assay: 14 mL.min-1.g-1
The estimate for compound 4 lay 1.2-fold (0.07 log units) below the measured number, and the stated range covers the measured number.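

In the liver assay, 4-hydroxy-2,2,6,6-tetramethylpiperidin-4-yl and 4-hydroxypiperidin-4-yl cannot be told apart on a saturated chain carbon bound to an oxygen on an aromatic ring, with a 1.1-fold lower number from compound 2 to compound 4 (0.06 log units; within the scatter), while the two open-chain amine groups stay separated from the new group only as far as a limit allows, with an at least 2.0-fold higher number from compound 3 to compound 4 (0.30 log units; that floor lies within the scatter) and an at least 2.0-fold higher number from compound 1 to compound 4 (0.30 log units; that floor lies within the scatter): the limit of < 7 mL.min-1.g-1 in the liver assay, at which 2 of the 4 values shown sit.

In a physicochemical assay for solubility, read by nephelometry, measured as kinetic solubility, with a stated time of 30 min (a lower number here means a less soluble compound, a higher number a more soluble compound), compound 3 gives 50 ug/mL, and the same exchange reads an at least 2.0-fold higher number from compound 3 to compound 4 (0.30 log units; that floor lies within the scatter). In the physicochemical assay compound 4 returns only a limit, > 100 ug/mL: the limit of > 100 ug/mL in the physicochemical assay, at which 1 of the 2 values shown sits.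

From the compounds shown here alone, it remains open which part of the entering group goes with the number in the liver assay, since the hydroxyl and the ring always occur together here, and a piperidin-4-yl group without the hydroxyl, or a hydroxyl-bearing open chain, would separate the two. Going by these compounds, the true size of the gap from the two open-chain compounds to compound 4 also stays open, as does any upper end of the reading for compound 4 in the physicochemical assay.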